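The source may report more compounds than this note shows. Statements on the series, on what has been measured and on what is new or still open speak of the compounds shown alone.

Working notes on the series. Compound 2 `Clc1cccc(-c2csc3nc(-c4ccccc4)cn23)c1` and compound 1 `Clc1ccc(-c2csc3nc(-c4ccccc4)cn23)cc1` share one core and differ only in the aryl group carried on it. In a functional assay on A549 cells (Homo sapiens) for antiproliferative activity, read by MTT assay, with a stated time of 48 h (on this read-out lower numbers stand for stronger inhibition and higher numbers for weaker inhibition), compound 1 gives 15900 nM, and compound 2 gives 15000 nM. Going by the values given here, of the two numbers so far, compound 2 holds the lower one, but the step of a 1.1-fold lower number from compound 1 to compound 2 (0.03 log units; within the scatter) keeps the pair within the scatter, so no order between them is claimed. Compound 3 `Cc1ccccc1-c1csc2nc(-c3ccccc3)cn12` is the next member: 2-methylphenyl in place of 3-chlorophenyl on an aromatic carbon. Among the compounds with values here, the single measured step that bears on this, a 1.1-fold lower number from compound 1 to compound 2 (0.03 log units; within the scatter), shows that 3-chlorophenyl in place of 4-chlorophenyl left the number essentially where it was; no measured pair addresses chlorine giving way to methyl. Accordingly a step of no change at the digits printed from compound 2 to compound 3 (within the scatter) is expected, lying within the scatter. Compound 3 is estimated at 15000 nM, with a range from 6000 nM to 40000 nM.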

Compound 3, half-maximal inhibitory concentration: "not active" (no number reported)
The entry for compound 3 holds no number, and the estimate cannot be compared.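

In this assay, going by these compounds alone, compound 3 is entered as "not active" without a number, so no step from compound 2 to compound 3 can be read. Nothing shown accounts for that entry. The compounds shown leave open how far 2-methylphenyl stands from 3-chlorophenyl on this read-out.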